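The source may hold more compounds than are shown below. What is called first, only, known or untested is meant among the compounds shown, and "the series" means these compounds.

Measured so far:
- compound 1, `OC[C@H]1O[C@@H](n2cnc3c(NCc4ccc(Cl)c(Cl)c4)ncnc32)[C@H](O)[C@@H]1O` — 145000 nM
- compound 2, `COc1ccc(CNc2ncnc3c2ncn3[C@@H]2O[C@H](CO)[C@@H](O)[C@H]2O)c(OC)c1` — "not determined" (no result reported)
- compound 3, `OC[C@H]1O[C@@H](n2cnc3c(NCc4ccc(F)cc4F)ncnc32)[C@H](O)[C@@H]1O` — > 166000 nM

In a functional assay on G-361 cells (Homo sapiens) for antiproliferative activity, with a stated time of 72 h (on this read-out higher numbers stand for weaker inhibition and lower numbers for stronger inhibition), compound 1 gives 145000 nM. For compound 2 no result is recorded in this assay, "not determined" (no result reported). Within the data shown here, compound 3 returns only a limit of this assay, > 166000 nM, and no single number, so compound 3 stands at the limit of > 166000 nM in this assay, at which 1 of the 3 values shown sits; with compound 2 lacking a number, compound 1 is the only member with a defined value.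

Among the measured compounds shown here, the one measured step, an at least 1.1-fold higher number from compound 1 to compound 3 (0.05 log units; that floor lies within the scatter), covers the change of the group on the saturated chain carbon bound to a nitrogen on an aromatic ring and lies within the scatter at its floor. Compound 4, `OC[C@H]1O[C@@H](n2cnc3c(NCc4ccc(C(F)(F)F)cc4)ncnc32)[C@H](O)[C@@H]1O`, differs from compound 3 by 4-(trifluoromethyl)phenyl in place of 2,4-difluorophenyl on a saturated chain carbon bound to a nitrogen on an aromatic ring. This is a change of the same kind and at the same place as the measured step, and that step gave no movement beyond the scatter.

On that basis compound 4 is expected to remain near the limit in this assay, with an expected step that the limit leaves unreadable from compound 3 to compound 4. The estimate for compound 4 is 170000 nM, expected to lie between 80000 nM and 400000 nM, with a fair chance that this assay again reports only a limit.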

Compound 4, half-maximal inhibitory concentration: > 166000 nM
Compound 4 was reported as a limit; the forecaster's own chance of this, stated with the estimate: 60%; the middle value does not contradict the limit.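

In this assay compound 4 gives only a limit and no single number, as compound 3 does, so replacing 2,4-difluorophenyl with 4-(trifluoromethyl)phenyl on the saturated chain carbon bound to a nitrogen on an aromatic ring, which takes the group from 8 to 10 heavy atoms, yields no defined value. Among these compounds, compound 1 remains the only member with a defined value, and the comparison with it shows an at least 1.1-fold higher number from compound 1 to compound 4 (0.05 log units; that floor lies within the scatter), while the steps between the limits cannot be read. With compound 2 having no result, no change at this place has yet given a step shown to lie beyond the scatter, and the limit is now shared: the limit of > 166000 nM in this assay, at which 2 of the 4 values shown sit.

The limits leave open how far compound 3 and compound 4 actually lie from compound 1 in this read-out, and whether they differ from each other at all. Also open, from the compounds shown here alone, is whether a phenyl ring carrying an amine or a carboxylic acid, or a longer chain between the nitrogen and the ring, would give a value clearly apart from that of compound 1.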